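Swapping a dimethylphenyl for a difluorophenyl on the amide

This account rests on a few compounds, and the source may have more. Where it says the series, first, only, none or still open, it means among the compounds named here.

Of the compounds shown here, two sharing one core have been measured in a functional assay on HepG2 cells (Homo sapiens) for antiproliferative activity, read by CCK-8 assay, with a stated time of 72 h; on this read-out lower numbers stand for stronger inhibition and higher numbers for weaker inhibition. Compound 1 `O=C(Nc1cccc(-c2oc3cc(-c4ccc(F)cc4)ccc3c(=O)c2O)c1)c1ccc(F)cc1F` carries a 2,4-difluorophenyl on the amide carbonyl and gives 26400 nM. Compound 2 `Cc1cc(C)cc(C(=O)Nc2cccc(-c3oc4cc(-c5ccc(F)cc5)ccc4c(=O)c3O)c2)c1` carries a 3,5-dimethylphenyl in that position and gives 13400 nM. For the measured compounds named here, the step between them, a 2.0-fold lower number from compound 1 to compound 2 (0.29 log units; within the scatter), is the only step known so far. On the numbers shown, compound 2 has the lower of the two values, though the gap to compound 1 is within the scatter, so neither compound can be called the stronger.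

Compound 3 `O=C(Nc1cccc(-c2oc3cc(-c4ccc(F)cc4)ccc3c(=O)c2O)c1)c1cc(F)cc(F)c1` is the next compound. It differs from compound 2 by 3,5-difluorophenyl in place of 3,5-dimethylphenyl on a carbonyl carbon. This change returns to a difluorophenyl, as in compound 1, but with the two fluorines in other positions, and brings a group of the same size as the one that leaves. Going by the values given here, the one relevant step, from compound 1 to compound 2, was within the scatter, so no step beyond the scatter is expected in this assay from compound 2 to compound 3; the expected step is a 1.5-fold higher number from compound 2 to compound 3 (0.17 log units; within the scatter). Compound 3 is therefore estimated at 20000 nM, within a range from 8000 nM to 50000 nM.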

Compound 3, half-maximal inhibitory concentration: 4960 nM
Estimate against measurement, compound 3: 4.0-fold (0.61 log units) above, and the stated range ends above it.
By their numbers in this assay, from the lowest: compound 3; then compounds 2 and 1 (each within the scatter of the next).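

In this assay, the group on the amide carbonyl now shows a step beyond the scatter: 3,5-difluorophenyl in place of 3,5-dimethylphenyl gives a 2.7-fold lower number from compound 2 to compound 3 (0.43 log units; beyond the scatter), even though both groups have the same count of heavy atoms and one carbon-only aromatic ring. Compound 1 and compound 3 both carry a difluorophenyl and differ only in where the two fluorines sit, yet the change gives a 5.3-fold lower number from compound 1 to compound 3 (0.73 log units; beyond the scatter), so at this position having two fluorines on the ring does not settle the result, and their placement counts as well. Compound 3 therefore has the lowest number of the three, but no measurement on these compounds accounts for either step.

From the compounds shown here alone, with only two fluorine placements to compare, no general rule for this ring can be drawn, and it remains open whether a single fluorine, two chlorines or two methoxy groups would lower the number further. Also open, going by these compounds, is whether a pyridine ring could stand in place of the phenyl ring, and whether the 3,5-difluorophenyl keeps its edge when the rest of the molecule changes.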